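This account rests on a few compounds, and the source may have more. Where it says the series, first, only, none or still open, it means among the compounds named here.

Measured compounds:
compound 1 `COc1cc(OC)c2c(=O)c(OCCCCOc3ccccc3/C=C/C(=O)/C=C/c3ccco3)c(-c3cc(OC)c(OC)c(OC)c3)oc2c1` — 7900 nM
compound 2 `COc1cc(OC)c2c(=O)c(OCCCCOc3ccccc3/C=C/C(=O)/C=C/c3ccc(Cl)cc3)c(-c3cc(OC)c(OC)c(OC)c3)oc2c1` — 18600 nM
compound 3 `COc1cc(OC)c2c(=O)c(OCCCCOc3ccccc3/C=C/C(=O)/C=C/c3cccs3)c(-c3cc(OC)c(OC)c(OC)c3)oc2c1` — 20500 nM

In a functional assay on MGC-803 cells (Homo sapiens) for antiproliferative activity, read by MTT assay, with a stated time of 48 h (a lower number here means a stronger inhibitor, a higher number a weaker inhibitor), compound 3 holds the highest number of the three; the gap to compound 2 is within the scatter, while a 2.6-fold higher number from compound 1 to compound 3 (0.41 log units; beyond the scatter) lies beyond it. Compound 4 `COc1cc(OC)c2c(=O)c(OCCCCOc3ccccc3/C=C/C(=O)/C=C/c3cccc([N+](=O)[O-])c3)c(-c3cc(OC)c(OC)c(OC)c3)oc2c1` differs from compound 3 in one place: 3-nitrophenyl in place of thiophen-2-yl on a double-bonded chain carbon bound to a double-bonded chain carbon. The step that bears most directly is a 1.1-fold higher number from compound 2 to compound 3 (0.04 log units; within the scatter), which shows that a six-membered carbon-only ring on this chain carbon gave a number indistinguishable from the thiophen-2-yl analogue. Going by the values given here, no measured step contains a nitro group, so the effect of that substitution is unknown here. A change within the scatter is therefore expected, with a 1.4-fold lower number from compound 3 to compound 4 (0.14 log units; within the scatter) leaning slightly toward a lower number. Compound 4 is estimated at 15000 nM, with a range of 6000 nM to 40000 nM.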

Compound 4, half-maximal inhibitory concentration: 5060 nM
Beside the measured number, compound 4's estimate is 3.0-fold (0.47 log units) above it, and the stated range ends above it.
By their numbers in this assay, from the lowest: compounds 4 and 1 (each within the scatter of the next); then compounds 2 and 3 (each within the scatter of the next).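

In this assay, 3-nitrophenyl on this chain carbon gives a 4.1-fold lower number from compound 3 to compound 4 (0.61 log units; beyond the scatter) and a 3.7-fold lower number from compound 2 to compound 4 (0.57 log units; beyond the scatter), so a six-membered aromatic ring of carbon only is not tied to the higher numbers seen so far. With a 1.6-fold lower number from compound 1 to compound 4 (0.19 log units; within the scatter), the 3-nitrophenyl and furan-2-yl analogues cannot be told apart, although their rings differ. No measurement on hand explains these differences. Going by these compounds, it remains open whether the nitro group itself matters, and whether 3-aminophenyl or 3-carboxyphenyl at this place would give a similar number.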